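Estimating a chloro analogue's lipophilicity from three measured compounds

The source may hold more compounds than are shown below. What is called first, only, known or untested is meant among the compounds shown, and "the series" means these compounds.

Compound 1, `COc1cc(-c2cc(C(=O)O)c3ccccc3n2)ccc1OCC(=O)Nc1ccccc1`, gives 0.7 in a physicochemical assay for lipophilicity, using the shake flask method, in phosphate buffer, measured as octanol-water partition, at pH 7.4; on this read-out higher numbers stand for higher lipophilicity and lower numbers for lower lipophilicity.
Compound 2, `COc1cc(-c2cc(C(=O)O)c3ccccc3n2)ccc1OCC(=O)Nc1cccc(C)c1`, gives 1.5 in this assay.
Compound 3, `COc1cc(-c2cc(C(=O)O)c3ccccc3n2)ccc1OCC(=O)Nc1cccc(F)c1`, gives 1.6 in this assay.

Among the compounds with values here, compound 3 shows the largest of the three numbers, but the step of a number 0.10 log units higher from compound 2 to compound 3 (within the scatter) is within the scatter, so compound 2 and compound 3 cannot be told apart; only the step of a number 0.90 log units higher from compound 1 to compound 3 (beyond the scatter) is beyond it.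

Compound 4, `COc1cc(-c2cc(C(=O)O)c3ccccc3n2)ccc1OCC(=O)Nc1ccc(Cl)cc1`, differs from compound 3 by 4-chlorophenyl in place of 3-fluorophenyl on an amide-type nitrogen. Within the data shown here, no measured step swaps fluoro for chloro, and none moves a group to a different carbon of that ring, so this change is only partly covered. What the measured steps do show is that adding either methyl or fluoro on an aromatic carbon raised the number by modest amounts, a number 0.80 log units higher from compound 1 to compound 2 (beyond the scatter) and a number 0.90 log units higher from compound 1 to compound 3 (beyond the scatter), while methyl against fluoro, a number 0.10 log units higher from compound 2 to compound 3 (within the scatter), stayed within the scatter. On that basis a small upward step, possibly beyond the scatter, is expected, a number 0.40 log units higher from compound 3 to compound 4 (beyond the scatter), though with real uncertainty in both directions. Compound 4 is therefore estimated at 2, with an expected range from 1.5 to 2.6.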

Compound 4, distribution coefficient: 1.5
Compound 4: the middle estimate sits 0.50 log units above what was measured, and the stated range covers the measured number.
By their numbers in this assay, from the lowest: compound 1; then compounds 2, 4 and 3 (each within the scatter of the next).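

Chloro on the aromatic ring gives a modest rise of the same kind that methyl and fluoro gave, with a number 0.80 log units higher from compound 1 to compound 4 (beyond the scatter) in this assay. The swap to 4-chlorophenyl changes both the group and the ring carbon that carries it, yet a number 0.10 log units lower from compound 3 to compound 4 (within the scatter) and no change at the digits printed from compound 2 to compound 4 (within the scatter), so compound 4 cannot be told apart from compound 2 or compound 3. Across these four compounds, the only clear difference is therefore between the bare ring of compound 1 and the three rings carrying a group, while methyl, fluoro and chloro remain indistinguishable from one another, and nothing available explains this result.

On these data alone, whether the ring carbon carrying the group matters on its own stays open, as telling that apart from the change of group would take one group compared on two different carbons of this ring. As far as these compounds go, it is also open whether the shared level among compounds 2, 3 and 4 would hold for groups of another kind on that ring, such as an amine, a nitrile or a longer chain.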